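The compounds below may be only part of what the source reports. "The series", "measured", "known", "first", "only" and "open" are said of these compounds alone.

Going by the values given here, in a functional assay on MCF7 cells (Homo sapiens) for cytotoxicity, read by MTT assay (a lower number here means a stronger inhibitor, a higher number a weaker inhibitor), compound 3 `CC(=O)O[C@@H]1OC(=O)[C@@](Cc2ccccc2)(C(C)=O)[C@@H]1C` gives 51000 nM, the only outright number among the three measured compounds. Compound 2 `CC(=O)O[C@@H]1OC(=O)[C@@](C)(C(C)=O)[C@@H]1C` reaches only a limit of the assay, > 10000 nM. Compound 1 `CC(=O)O[C@@H]1OC(=O)[C@](O)(C(C)=O)[C@@H]1C` likewise sits at a limit, > 50000 nM. Among the compounds with values here, the one measured step, a step that the limit leaves unreadable from compound 2 to compound 3, cannot be read in size because the limit of > 10000 nM in this assay, at which 1 of the 3 values shown sits, hides where compound 2 truly lies, and the limit of > 50000 nM in this assay, at which 1 of the 3 values shown sits, marks a second value as a limit rather than a number.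

Compound 4 `CC(=O)O[C@@H]1OC(=O)[C@@](O)(C(C)=O)[C@@H]1C` differs from compound 3 by hydroxy in place of benzyl on a saturated ring carbon. Within the data shown here, no measured step mirrors this change: the step from compound 2 to compound 3 is unreadable, and compound 1, which carries the same hydroxy group on that ring carbon in the opposite spatial arrangement, gave a limit rather than a number. Given compound 3 at 51000 nM, and nothing measured to suggest a gain, any shift is expected to stay within the scatter or to weaken the compound further. Compound 4 is therefore estimated at 60000 nM, with a range from 20000 nM to 200000 nM. That estimate means a step of a 1.2-fold higher number from compound 3 to compound 4 (0.07 log units; within the scatter), expected to lie within the scatter.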

Compound 4, half-maximal inhibitory concentration: > 50000 nM
Compound 4: no number, only a limit; the forecaster's own chance of this, stated with the estimate: 70%; the middle value lies beyond the limit too.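

The result for compound 4 is only a limit, not a number, so none of its steps from compound 1, compound 2 or compound 3 can be read in size. The compounds shown leave open whether compound 1 and compound 4, drawn with opposite configuration at one ring carbon, truly differ in this assay.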